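Amide to urea on the biaryl series: a short note

The source may report more compounds than this note shows. Statements on the series, on what has been measured and on what is new or still open speak of the compounds shown alone.

Measured so far:
compound 1, `COC(=O)/C=C/c1cccc(N(Cc2ccc(/C=C/c3ccccc3F)cc2)C(=O)NC(C)C)c1`, 431 nM
compound 2, `COC(=O)/C=C/c1cccc(N(Cc2ccc(-c3cccc(Cl)c3)cc2)C(=O)C(C)C)c1`, 77 nM

In an assay on isolated protein with Bile acid receptor (Homo sapiens) as the target (a lower number here means that less compound is needed, a higher number that more compound is needed for the effect), compound 2 gives 77 nM, the lowest of the two numbers; compound 1 gives 431 nM, a gap beyond the scatter. The two differ in more than one place, so no single step can be read from them.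

Compound 3, `COC(=O)/C=C/c1cccc(N(Cc2ccc(-c3cccc(Cl)c3)cc2)C(=O)NC(C)C)c1`, is compound 2 with isopropylamino in place of isopropyl on a carbonyl carbon, that is, isopropylcarbonyl to isopropylcarbamoyl. Compound 1 carries the same isopropylcarbamoyl group, but on a different aryl part, so its number does not isolate this change. A step of about the size of the scatter, or a little beyond it, towards a higher number is expected for this change, a 1.8-fold higher number from compound 2 to compound 3 (0.26 log units; within the scatter). For compound 3 in this assay the estimate is 140 nM, with a range from 40 nM to 500 nM.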

Compound 3, half-maximal effective concentration: 1400 nM
The estimate for compound 3 lay 10-fold (1.00 log units) below the measured number; measured number above the stated range.
By their numbers in this assay, from the lowest: compound 2; then compound 1; then compound 3.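

In this assay, this carbonyl position does not tolerate the exchange of groups: with the 3-chlorophenyl part kept, isopropylamino in place of isopropyl gives an 18-fold higher number from compound 2 to compound 3 (1.26 log units; beyond the scatter), a large step. With isopropylcarbamoyl kept, the aryl part also counts, as 3-chlorophenyl in place of 2-(2-fluorophenyl)ethenyl gives a 3.2-fold higher number from compound 1 to compound 3 (0.51 log units; beyond the scatter), a modest step, so 3-chlorophenyl brings no gain in this setting. No data available here explain either step.

Still open, on these data alone, is whether the aryl step would keep its direction and size with isopropylcarbonyl in place of isopropylcarbamoyl, which the three compounds cannot show. Also open, as far as these compounds go, is whether a dimethylamino group on the same carbonyl carbon would read like isopropylamino or like isopropyl.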